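The source may report more compounds than this note shows. Statements on the series, on what has been measured and on what is new or still open speak of the compounds shown alone.

Compound 1 `Cc1ccc(S(=O)(=O)N2C=CNC(=O)[C@H]2CC(=O)N[C@@H]2CCC(O)c3ccccc32)cc1` and compound 2 `CCCN1CC[C@H](NC(=O)C[C@@H]2C(=O)NC=CN2S(=O)(=O)c2ccc(C)cc2)C(C)(C)C1` share the same core and have both been tested in an in vitro ADME assay on microsomes from liver (Homo sapiens) for pharmacokinetics; a higher number here means faster removal of the compound, a lower number slower removal. Compound 1 gives only a limit of the assay, < 50 mL.min-1.g-1, and not a number. Compound 2 also gives only a limit, < 50 mL.min-1.g-1. Compound 2 therefore stands at the limit of < 50 mL.min-1.g-1 in this assay, at which 2 of the 2 values shown sit, so the data give no number for it, only this limit. Compound 3 `Cc1ccc(S(=O)(=O)N2C=CNC(=O)[C@H]2CC(=O)N[C@H]2CCN(C3CCCC3)CC2(C)C)cc1` has not yet been measured. It differs from compound 2 by one change, (cyclopentyl in place of propyl on an amine nitrogen in a ring), with cyclopentyl in place of propyl on an amine nitrogen in a ring. Within the data shown here, no measured step between compounds shows what such a change does in this assay. The expected step, a step that the limit leaves unreadable from compound 2 to compound 3, is therefore none beyond the scatter, in either direction. Compound 3 is estimated at 40 mL.min-1.g-1, with an expected range from 18 mL.min-1.g-1 to 90 mL.min-1.g-1.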

Compound 3, intrinsic clearance in microsomes: < 14 mL.min-1.g-1
Compound 3 ended at the assay's limit (the forecaster's own chance of this, stated with the estimate: 60%); middle value at least 2.8-fold (0.45 log units) from the limit.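

Compound 2 and compound 3 both give only limits in this assay, and the step between them, cyclopentyl in place of propyl on an amine nitrogen in a ring, cannot be read. The compounds shown leave open what intrinsic clearance either compound actually has, and whether this change alters it at all.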